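The source may report more compounds than this note shows. Statements on the series, on what has been measured and on what is new or still open speak of the compounds shown alone.

Measured compounds in a functional assay on A549 cells (Homo sapiens), read by MTT assay, with a stated time of 72 h; on this read-out higher numbers stand for weaker inhibition and lower numbers for stronger inhibition:
- compound 1 `COc1nc(N)nc2c1c(-c1cc3ccccc3o1)cn2[C@@H]1O[C@H](CO)[C@@H](O)[C@H]1O`: > 20000 nM, a limit of the assay.
- compound 2 `COc1ncnc2c1c(I)cn2[C@@H]1O[C@H](CO)[C@@H](O)[C@H]1O`: > 20000 nM, also a limit.
- compound 3 `COc1ncnc2c1c(-c1ccco1)cn2[C@@H]1O[C@H](CO)[C@@H](O)[C@H]1O`: 30 nM.

For the measured compounds named here, compound 3 gives the only number in this assay; the other two values are limits, (the limit of > 20000 nM in this assay, at which 2 of the 3 values shown sit). Going by the values given here, the one measured step, an at least 660-fold lower number from compound 2 to compound 3 (2.82 log units; beyond the scatter), concerns a different change and so bears only loosely on the present one. Compound 4 `COc1ncnc2c1c(-c1cc3ccccc3o1)cn2[C@@H]1O[C@H](CO)[C@@H](O)[C@H]1O` differs from compound 3 by 1-benzofuran-2-yl in place of furan-2-yl on an aromatic carbon. Compound 1 also carries 1-benzofuran-2-yl yet sits at the limit, but it differs from compound 4 at a second site, so its value alone cannot fix the outcome. Compound 4 is therefore expected to give 150 nM (range 20 nM to 5000 nM), a step of a 5.0-fold higher number from compound 3 to compound 4 (0.70 log units; beyond the scatter), with real risk of a limit.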

Compound 4, half-maximal inhibitory concentration: 17700 nM
Compound 4: the middle estimate sits 120-fold (2.07 log units) below what was measured, and the stated range ends below it.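

In this assay, 1-benzofuran-2-yl in place of furan-2-yl on an aromatic carbon gives a large step, a 590-fold higher number from compound 3 to compound 4 (2.77 log units; beyond the scatter), so the gain seen for furan-2-yl in place of iodo, an at least 660-fold lower number from compound 2 to compound 3 (2.82 log units; beyond the scatter), does not extend to 1-benzofuran-2-yl. Compound 4 keeps a measurable value, but the steps to it, an at least 1.1-fold lower number from compound 2 to compound 4 (0.05 log units; that floor lies within the scatter) and an at least 1.1-fold lower number from compound 1 to compound 4 (0.05 log units; that floor lies within the scatter), cannot be read: the limit of > 20000 nM in this assay, at which 2 of the 4 values shown sit.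

The effect of amino on the core therefore stays unresolved. Also open, from the compounds shown here alone, is whether a thiophene in place of the furan, or a methyl or carboxylic acid on furan-2-yl, keeps the value of compound 3.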